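Branched alkyl ether in place of a tert-butoxy-bearing chain

The source may hold more compounds than are shown below. What is called first, only, known or untested is meant among the compounds shown, and "the series" means these compounds.

Compounds measured so far in an assay on cells with melanin-concentrating hormone receptor 1 (Homo sapiens) as the target, read by radioligand binding; on this read-out lower numbers stand for stronger inhibition and higher numbers for weaker inhibition:
- compound 1, `CCC(C)COc1cccc2ccc(N)nc12`: 36 nM
- compound 2, `Nc1ccc2cccc(OCCC(F)(F)F)c2n1`: 722 nM
- compound 3, `CC(COC(C)(C)C)Oc1cccc2ccc(N)nc12`: 306 nM

All three share one core and differ only in the chain attached through an oxygen on the aromatic ring. Compound 3 stands second highest of the three numbers: compound 2 gives 722 nM, and compound 1 gives 36 nM, so compound 3 sits in between, closer to compound 2.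

Compound 4, `CCCC(C)Oc1cccc2ccc(N)nc12`, is not yet measured. It differs from compound 3 by ethyl in place of tert-butoxy on a saturated chain carbon, two bonds along the chain from an oxygen on an aromatic ring. Among the measured compounds shown here, the only step that has been measured on this series is a 20-fold higher number from compound 1 to compound 2 (1.30 log units; beyond the scatter), which concerns the carbon bound to the oxygen and shows that the chain on this oxygen can move the number a long way. The change from compound 3 to compound 4 removes the tert-butoxy and leaves a plain branched alkyl chain, which brings compound 4 close in kind to compound 1. Since compound 1 gives 36 nM while compound 3 gives 306 nM, compound 4 is expected to give a lower number than compound 3, an estimated step of a 5.1-fold lower number from compound 3 to compound 4 (0.71 log units; beyond the scatter). Compound 4 is therefore estimated at 60 nM, with a range of 25 nM to 150 nM.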

Compound 4, half-maximal inhibitory concentration: 105 nM
Compound 4: middle estimate off by 1.8-fold (0.24 log units), on the low side, and the stated range covers the measured number.
By their numbers in this assay, from the lowest: compound 1; then compound 4; then compound 3; then compound 2.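

In this assay, ethyl in place of tert-butoxy gives a 2.9-fold lower number from compound 3 to compound 4 (0.46 log units; beyond the scatter) and 1-methylbutyl in place of 3,3,3-trifluoropropyl gives a 6.9-fold lower number from compound 2 to compound 4 (0.84 log units; beyond the scatter) on the same oxygen, so the plain branched chain of compound 4 reads lower than both the chain with the ether oxygen and the fluorinated chain. Plain branched chains are not interchangeable here either: 1-methylbutyl in place of 2-methylbutyl gives a 2.9-fold higher number from compound 1 to compound 4 (0.46 log units; beyond the scatter) even though neither chain carries fluorine or tert-butoxy, so a change in the chain's branching alone moves the number beyond the usual scatter. Nothing available here explains why any of these chains reads as it does.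

With only four chains in view, the shown compounds leave open whether a ring on the oxygen, such as cyclopentyl or cyclohexyl, would read closer to the 2-methylbutyl chain of compound 1 or to the 1-methylbutyl chain of compound 4. They also leave open how a longer chain, or a chain ending in an amine or a carboxylic acid, would read on this oxygen.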